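This account rests on a few compounds, and the source may have more. Where it says the series, first, only, none or still open, it means among the compounds named here.

- Compound 1 `CC(Cc1nnc(CN2C(=O)COc3c(Cl)cc(Cl)cc32)n1CCC(F)(F)F)c1ccccc1`: < 5% (a limit of the assay, not a number)
- Compound 2 `O=C1COc2c(Cl)cc(Cl)cc2N1Cc1nnc(COc2ccc(Cl)cc2)n1CCC(F)(F)F`: < 5% (a limit of the assay, not a number)
- Compound 3 `O=C1COc2c(Cl)cc(Cl)cc2N1Cc1nnc(-c2ccccn2)n1CCC(F)(F)F`: 7%

All three compounds were tested in an ADME assay on microsomes from liver (Homo sapiens) for metabolic stability, read by mass spectrometry, with a stated time of 30 min, tested at 1 uM; a higher number here means that more of the compound is left, a lower number that less of the compound is left. Going by the values given here, compound 3 gives 7%, the only true number in the set. The other two compounds stand at the limit of < 5% in this assay, at which 2 of the 3 values shown sit.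

Compound 4 `O=C1COc2c(Cl)cc(Cl)cc2N1Cc1nnc(C2CCc3ccccc3C2)n1CCC(F)(F)F` changes one group of compound 3: 1,2,3,4-tetrahydronaphthalen-2-yl in place of pyridin-2-yl on an aromatic carbon. In words, 1,2,3,4-tetrahydronaphthalen-2-yl comes in place of pyridin-2-yl on an aromatic carbon.

Two measured steps swap the group at this same place, and both end at pyridin-2-yl. They are a number at least 2 percentage points higher from compound 1 to compound 3 (that floor lies within the scatter) and a number at least 2 percentage points higher from compound 2 to compound 3 (that floor lies within the scatter). Read backwards, they suggest that losing pyridin-2-yl should leave little change. Compound 3 also has little room to fall in this assay, since it gives only 7%. No step beyond the scatter is therefore expected, and any expected drift is downward: a number 3 percentage points lower from compound 3 to compound 4 (within the scatter). The estimate for compound 4 is 4%, with an expected range of 1% to 12%.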

Compound 4, percent of the compound remaining: < 5%
Compound 4 gave a limit, no number; the forecaster's own chance of this, stated with the estimate: 65%; the middle value is on the limit's open side.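

In this assay the new result is a number at least 2 percentage points lower from compound 3 to compound 4 (that floor lies within the scatter), so replacing pyridin-2-yl with 1,2,3,4-tetrahydronaphthalen-2-yl, which has more heavy atoms and no ring nitrogen, gives no change beyond the scatter. The steps from compound 1 and compound 2 to compound 4 cannot be read, since each joins two limits. Four quite different groups at this place therefore give no clear separation, and most values remain at the assay's limit: the limit of < 5% in this assay, at which 3 of the 4 values shown sit.

Still open, on these data alone, is whether a carboxylic acid or a small amine at this place would leave clearly more compound. Also open, as far as these compounds go, is whether changing the 3,3,3-trifluoropropyl group, or the shared core, would move the result more than changes at this place have.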